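This account rests on a few compounds, and the source may have more. Where it says the series, first, only, none or still open, it means among the compounds named here.

Measured in a functional assay on MCF7 cells (Homo sapiens) for antiproliferative activity, read by CCK-8 assay, with a stated time of 72 h (a higher number here means a weaker inhibitor of growth, a lower number a stronger inhibitor of growth), so far:
- compound 1 `CCC1C(=O)N(C)c2cnc(Nc3ccc(S(=O)(=O)NC)cc3)nc2N1c1ccn(C)n1` gives 3750 nM
- compound 2 `CC[C@@H]1C(=O)N(C)c2cnc(Nc3ccc(S(=O)(=O)NC)cc3)nc2N1C1CCCC1` gives 151 nM
- compound 3 `CC[C@@H]1C(=O)N(C)c2cnc(Nc3ccc(S(=O)(=O)Nc4ccccc4)cc3)nc2N1C1CCCC1` gives 5430 nM

Compound 3 lies within the usual scatter of compound 1, and its number is far higher than that of compound 2. So, of these three, only compound 2 stands apart as a clearly stronger inhibitor of growth.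

The next compound is compound 4 `CC[C@@H]1C(=O)N(C)c2cnc(Nc3ccc(S(=O)(=O)NCC(C)C)cc3)nc2N1C1CCCC1` and it has not yet been measured. It differs from compound 3 in one place only, with isobutyl in place of phenyl on a sulfonamide nitrogen.

Among the compounds with values here, one measured step bears directly on this change, since it involves the same nitrogen. With phenyl in place of methyl, the result was a 36-fold higher number from compound 2 to compound 3 (1.56 log units; beyond the scatter) and that step is large. Compound 4 carries a chain like compound 2 rather than a ring like compound 3, so part of that large step should be reversed. Within the data shown here, no isobutyl compound has been measured, however, so how much is reversed remains uncertain, and the range must be wide.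

In this assay the expected change is a 6.0-fold lower number from compound 3 to compound 4 (0.78 log units; beyond the scatter) as a rough estimate. For compound 4 the estimated value is 900 nM with an expected range from 250 nM to 3500 nM around it.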

Compound 4, concentration for 50% growth inhibition: 403 nM
Compound 4: middle estimate off by 2.2-fold (0.35 log units), on the high side, within the range that was stated.
By their numbers in this assay, from the lowest: compound 2; then compound 4; then compounds 1 and 3 (each within the scatter of the next).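

In this assay, this sulfonamide nitrogen can carry a group larger than methyl without a severe penalty: replacing the phenyl ring with the open isobutyl chain gives a 13-fold lower number from compound 3 to compound 4 (1.13 log units; beyond the scatter), which recovers most of the ground lost with phenyl. The recovery is incomplete, since adding isopropyl in place of hydrogen on the saturated chain carbon bound to the sulfonamide nitrogen gives a 2.7-fold higher number from compound 2 to compound 4 (0.43 log units; beyond the scatter), a modest step. With three groups now compared here, the number rises from methyl to isobutyl to phenyl, so the change in the group matters at this position, and the phenyl of compound 3 costs far more than the isobutyl of compound 4. No measurement shown explains why these groups differ in this way.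

From the compounds shown here alone, it remains open whether the phenyl penalty comes from the aromatic ring itself or from the number of atoms, a question that cyclohexyl or benzyl on the same nitrogen would help to settle. Going by these compounds, it is also open whether the unsubstituted sulfonamide, or a chain ending in an amine or a carboxylic acid, would match or improve on methyl.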